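The source may hold more compounds than are shown below. What is called first, only, known or untested is meant among the compounds shown, and "the series" means these compounds.

Measured in a functional assay on HeLa cells (Homo sapiens) for inhibition, read by MTT assay, with a stated time of 48 h (a higher number here means a weaker inhibitor, a lower number a stronger inhibitor), as follows:
- compound 1 `O=C(CC(c1ccc(F)cc1)C(C(=O)Nc1ccccn1)C(=O)Nc1ccccn1)c1ccc(F)cc1` gives 25500 nM
- compound 2 `O=C(CC(c1ccc([N+](=O)[O-])cc1)C(C(=O)Nc1ccccn1)C(=O)Nc1ccccn1)c1ccccc1` gives 30000 nM
- compound 3 `O=C(CC(c1ccc(Cl)cc1)C(C(=O)Nc1ccccn1)C(=O)Nc1ccccn1)c1ccc2ccccc2c1` gives "not active" (no number reported)

Going by the values given here, compound 2, at 30000 nM, lies within the scatter of compound 1, at 25500 nM, and both are the only numbers available. Compound 4 `Cc1cc(C)c(C(CC(=O)c2ccccc2)C(C(=O)Nc2ccccn2)C(=O)Nc2ccccn2)c(C)c1` carries 2,4,6-trimethylphenyl in place of 4-nitrophenyl on a saturated chain carbon bound to two saturated chain carbons. Among the compounds with values here, no measured step covers this change, so no shift beyond the scatter is expected in this assay, although compound 3 shows that a result without a number is possible. The expected change is small, an estimated 1.1-fold higher number from compound 2 to compound 4 (0.03 log units; within the scatter). For compound 4 the estimated value is 32000 nM, within a range of 12000 nM to 85000 nM.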

Compound 4, half-maximal inhibitory concentration: 15100 nM
Estimate against measurement, compound 4: 2.1-fold (0.33 log units) above, within the range that was stated.
By their numbers in this assay, from the lowest: compounds 4, 1 and 2 (each within the scatter of the next).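

Read in this assay the exchange of 4-nitrophenyl for 2,4,6-trimethylphenyl on a saturated chain carbon bound to two saturated chain carbons gives a 2.0-fold lower number from compound 2 to compound 4 (0.30 log units; within the scatter) and is the first step that can be read at this position. A group of carbon only, with no hydrogen-bond acceptors, thus stands in this place without a shift beyond the scatter. Nothing given here accounts for the result. Going by these compounds, whether an amine or a carboxylic acid in this place would move the number beyond the scatter stays open. Also open, on these data alone, is whether any single change here would separate two compounds at all.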